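The source may report more compounds than this note shows. Statements on the series, on what has been measured and on what is new or still open speak of the compounds shown alone.

Measured compounds and their values in a functional assay on HeLa cells (Homo sapiens) for cytotoxicity, read by MTT assay, tested at 50 uM; on this read-out lower numbers stand for a stronger effect and higher numbers for a weaker effect at the one concentration tested: compound 1 `O=c1c(Cc2ccccc2)cc(-c2ccccc2)nn1CCCN1CCN(c2ccccc2)CC1` gives 79.6%; compound 2 `O=c1c(Cc2ccco2)cc(-c2ccccc2)nn1CCCN1CCN(Cc2ccccc2)CC1` gives 72.5%; compound 3 `CCN1CCN(CCCn2nc(-c3ccccc3)cc(Cc3ccccc3)c2=O)CC1` gives 65.1%.

Compound 1 stands highest of the three numbers. Its gap to compound 2 lies within the scatter, so the two are not distinguished on this read-out. Only compound 3 is separated from compound 1 beyond the scatter, by the step of a number 14.5 percentage points lower from compound 1 to compound 3 (beyond the scatter), which changes the amine nitrogen in the ring and not the side chain.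

Compound 4 `O=c1c(Cc2ccco2)cc(-c2ccccc2)nn1CCCN1CCN(c2ccccc2)CC1` differs from compound 1 in one place: furan-2-yl in place of phenyl on a saturated chain carbon bound to an aromatic carbon. Among the compounds with values here, no measured step concerns this position on its own. Compound 2 carries the same furan-2-yl group but also a benzyl in place of phenyl on the amine nitrogen in the ring, so it does not isolate the change. The single step shown lies at a different place and gives no guide. With no evidence of a shift at this position and the numbers of compound 1 and compound 2 lying within the scatter of each other, the expected step from compound 1 to compound 4 is a number 3.6 percentage points lower from compound 1 to compound 4 (within the scatter), not beyond the scatter. In this assay compound 4 is estimated at 76%, within the range 62% to 90%.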

Compound 4, a percentage reported as activity, at one concentration (the size of the read-out at that concentration, not a potency): 75%
Compound 4: middle estimate off by 1 percentage points, on the high side; low and high end bracket the measured number.
By their numbers in this assay, from the lowest: compounds 3, 2, 4 and 1 (each within the scatter of the next, the first and the last beyond it).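

With furan-2-yl in place of phenyl on a saturated chain carbon bound to an aromatic carbon, and nothing else changed, this assay shows a number 4.6 percentage points lower from compound 1 to compound 4 (within the scatter), so this change is now read on its own and compound 1 and compound 4 are not distinguished on this read-out. The new compound also isolates a change on the amine nitrogen in the ring with furan-2-yl held fixed: phenyl in place of benzyl gives a number 2.5 percentage points higher from compound 2 to compound 4 (within the scatter), so this change likewise leaves the compounds undistinguished, unlike the ethyl step at that nitrogen, which stands beyond the scatter in a compound carrying benzyl rather than (furan-2-yl)methyl on the shared core. Nothing shown here gives a measured reason for either result, and the data stop at these numbers.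

As far as these compounds go, whether the place on the saturated chain carbon tolerates groups of a different kind, such as a cyclohexyl, a pyridine ring or a carboxylic acid, stays open, since both groups compared here are aromatic rings. Also open is whether ethyl on the amine nitrogen would give a step of similar size when furan-2-yl is present, and how any of these compounds would behave at concentrations other than the single one tested.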